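A few compounds are considered here, and "the series" means these few. Any claim that something is new, unique, unknown or untested is made for them only; others in the source may bear on it.

Measured in a functional assay on C8166 cells (Homo sapiens) for cytotoxicity, read by MTT assay, with a stated time of 72 h; on this read-out higher numbers stand for lower toxicity in this test and lower numbers for higher toxicity in this test:
- compound 1 `C/C(=N\NC(=O)Cn1c(=O)c(C)nc2ccccc21)c1ccccc1Cl`: > 543000 nM
- compound 2 `Cc1ccc(S(=O)(=O)N2CC3(C[C@H]2C(=O)NN)SCCS3)cc1`: > 519000 nM

Both values are limits, not numbers. Compound 2 is therefore known only by its limit of > 519000 nM. Within the data shown here, no measured step links compound 1 and compound 2, so the data give no size for any structural change.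

In compound 3 `Cc1ccc(S(=O)(=O)N2CC3(C[C@H]2C(=O)N/N=C/c2ccccc2Br)SCCS3)cc1`, the amino group of compound 2 leaves, and a group with one six-membered aromatic ring of carbon only enters on an amide-type nitrogen (a group of 9 heavy atoms (7 carbon, 1 nitrogen, 1 bromine; one six-membered aromatic ring of carbon only) in place of one nitrogen atom, on an amide-type nitrogen). A moderate move towards higher toxicity is expected, estimated as an at least 3.4-fold lower number from compound 2 to compound 3 (0.53 log units; beyond the scatter). For compound 3 the expected value is 150000 nM, with an estimated range of 30000 nM to 450000 nM.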

Compound 3, half-maximal cytotoxic concentration: 177000 nM
Beside the measured number, compound 3's estimate is 1.2-fold (0.07 log units) below it; the measured number falls inside the stated range.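

Among these compounds, compound 3 is the first compound here to give a number rather than a limit in this assay, so a change on this amide-type nitrogen can be seen in this test. Replacing the amino group with the group carrying the aromatic ring and bromine gives an at least 2.9-fold lower number from compound 2 to compound 3 (0.46 log units; beyond the scatter). That step is a bound and not an exact size, because compound 2 is known only by a limit: the limit of > 519000 nM in this assay, at which 1 of the 3 values shown sits.

The compounds shown leave open whether the bromine or the aromatic ring accounts for the change, and how a methoxy group or a chlorine in place of the bromine would read. Compound 1 differs from compound 3 in more than one place and does not bear on this change.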